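The source may hold more compounds than are shown below. What is called first, only, known or untested is meant among the compounds shown, and "the series" means these compounds.

In a functional assay on V79 cells (Cricetulus griseus) for cytotoxicity, read by colony formation (on this read-out higher numbers stand for weaker inhibition and lower numbers for stronger inhibition), compound 2 `CC1(CN)CCN(c2cc3c(cc2F)c(=O)c(C(=O)O)cn3C2CC2)C1` gives 23 ug/mL. Compound 3 `CC1(CN)CCN(c2c(F)cc3c(=O)c(C(=O)O)cn(C4CC4)c3c2F)C1` gives 8 ug/mL, the lower of these two single numbers, and the step between them is a 2.9-fold lower number from compound 2 to compound 3 (0.46 log units; beyond the scatter). Compound 1 `CCNCC1CCN(c2c(F)cc3c(=O)c(C(=O)O)cn(C4CC4)c3c2Cl)C1` gives 11 ug/mL; 11 ug/mL; < 11 ug/mL (3 entries). Compound 4 `CC1(CN)CCN(c2c(F)cc3c(=O)c(C(=O)O)cn(C4CC4)c3c2Cl)C1` has chloro in place of fluoro on an aromatic carbon of compound 3: chloro in place of fluoro on an aromatic carbon. Among the measured compounds shown here, the one measured step at that place, a 2.9-fold lower number from compound 2 to compound 3 (0.46 log units; beyond the scatter), was modest and put fluoro in place of hydrogen. Compound 1 also carries chloro there, but on a different side chain, so it is only indirect support. In this assay a small shift to a lower number is expected, with nothing beyond the scatter: the estimate is a 1.1-fold lower number from compound 3 to compound 4 (0.06 log units; within the scatter). For compound 4 the expected value is 7 ug/mL, with an estimated range of 3.5 ug/mL to 14 ug/mL.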

Compound 4, half-maximal inhibitory concentration: 8 ug/mL
For compound 4 the middle estimate is 1.1-fold (0.06 log units) below the measured one; the range from low to high includes it.
By their numbers in this assay, from the lowest: compounds 3 and 4 (each within the scatter of the next); then compound 2.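

Chloro in place of fluoro at this position gives no change at the digits printed from compound 3 to compound 4 (within the scatter), so this read-out does not tell the two halogens apart here. Chloro in place of hydrogen gives a 2.9-fold lower number from compound 2 to compound 4 (0.46 log units; beyond the scatter), which shows that the lower number is not particular to fluoro. No measurement shown gives a cause for this.

As far as these compounds go, whether a methyl group, a methoxy group or a nitrile at this position would give a similar number remains open. From the compounds shown here alone, it is also open whether chloro and fluoro would match on the side chain of compound 1.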